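The source may hold more compounds than are shown below. What is called first, only, known or untested is meant among the compounds shown, and "the series" means these compounds.

Of the compounds shown here, two from this series have been measured so far. Compound 2 `C[C@@H]1CCC=C2C(=O)C=C[C@@H](O)[C@]21C` is the smaller of the two, and in a functional assay on BV-2 cells (Mus musculus) for inhibition, read by ELISA and Griess assay (on this read-out lower numbers stand for stronger inhibition and higher numbers for weaker inhibition), compound 2 gives 3480 nM, the lowest of the two numbers. Compound 1 `C[C@@H]1C[C@H](O)C=C2C(=O)C=C[C@@H](C(C)(C)O)[C@]21C` carries both a hydroxy group on its saturated ring and a dimethyl carbinol in place of the hydroxy of compound 2; in this assay compound 1 gives 30500 nM, a higher number that lies beyond the usual scatter. Because compound 1 and compound 2 differ in two places at once, their two values alone do not show which of the two changes accounts for the gap.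

Compound 3 `C[C@@H]1C[C@H](O)C=C2C(=O)C=C[C@@H](O)[C@]21C` is the next compound, not yet measured. It differs from compound 2 in a single place: hydroxy in place of hydrogen on a saturated ring carbon. Among the measured compounds shown here, no measured pair isolates this change, so any expectation rests on the values of compound 1 and compound 2. The authors expect the step of a 2.3-fold higher number from compound 2 to compound 3 (0.36 log units; beyond the scatter) to be a modest weakening, possibly no more than the scatter. Compound 3 is estimated to give 8000 nM in this assay, within a range of 2500 nM to 30000 nM.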

Compound 3, half-maximal inhibitory concentration: 2430 nM
Compound 3: the middle estimate sits 3.3-fold (0.52 log units) above what was measured; the measured number lies below the stated range.
By their numbers in this assay, from the lowest: compounds 3 and 2 (each within the scatter of the next); then compound 1.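

In this assay, hydroxy in place of hydrogen on this saturated ring carbon gives a 1.4-fold lower number from compound 2 to compound 3 (0.16 log units; within the scatter), so this single change leaves compound 2 and compound 3 within the scatter of each other, and the read-out does not separate the hydrogen from the hydroxy at this carbon. The other single change can now be read as well: hydroxy in place of 1-hydroxy-1-methylethyl gives a 13-fold lower number from compound 1 to compound 3 (1.10 log units; beyond the scatter), a large step beyond the scatter, which places the gap seen between the two earlier compounds with the 1-hydroxy-1-methylethyl group and not with the ring hydroxy. Nothing at hand explains either of these two results.

The compounds shown leave open whether the ring carbon that carries the hydroxy in compound 3 would stay as undemanding with a larger or differently built group, such as a methoxy, an amine or a carboxylic acid. They also leave open how a methyl or an ethyl would read in place of the hydroxy that compound 3 keeps on the other saturated ring carbon, where 1-hydroxy-1-methylethyl stands in compound 1.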